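Replacing a long chain with a short hydroxyethoxy chain

The compounds below may be only part of what the source reports. "The series", "measured", "known", "first", "only" and "open" are said of these compounds alone.

Measured compounds:
Compound 1, `CCSCCn1c(N2CCN(C)CC2)nc2ccccc21`: 19 nM
Compound 2, `CCCOCCn1c(N2CCN(C)CC2)nc2ccccc21`: 20 nM
Compound 3, `CCCCCCCCCCn1c(N2CCN(C)CC2)nc2ccccc21`: 4200 nM

All three share one core and differ only in the chain attached to it. In a functional assay on ileum for inhibition of histamine H1 receptor (Cavia porcellus) (on this read-out lower numbers stand for stronger inhibition and higher numbers for weaker inhibition), compound 3 gives 4200 nM, the highest number of the three and therefore the weakest inhibition among them. Its octyl chain sets it far apart: the step of a 220-fold higher number from compound 1 to compound 3 (2.34 log units; beyond the scatter) and the step of a 210-fold higher number from compound 2 to compound 3 (2.32 log units; beyond the scatter) are both large, while compound 1 and compound 2, with their shorter chains containing a sulfur or an oxygen, sit close together, as the step of a 1.1-fold higher number from compound 1 to compound 2 (0.02 log units; within the scatter) shows.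

Compound 4, `CN1CCN(c2nc3ccccc3n2CCOCCO)CC1`, is the next candidate. The change from compound 3 is 2-hydroxyethoxy in place of octyl on a saturated chain carbon, two bonds along the chain from an aromatic nitrogen. The new group resembles the chains of compound 1 and compound 2 in length, and both of those gave far lower numbers than compound 3. The expectation for this assay is therefore a large drop, as in a 110-fold lower number from compound 3 to compound 4 (2.02 log units; beyond the scatter). Compound 4 is estimated at 40 nM, with a likely range from 10 nM to 200 nM.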

Compound 4, half-maximal inhibitory concentration: 42 nM
Estimate against measurement, compound 4: 1.1-fold (0.02 log units) below; measured number inside the range.
By their numbers in this assay, from the lowest: compounds 1 and 2 (each within the scatter of the next); then compound 4; then compound 3.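

In this assay, the position also accepts a chain carrying a hydroxy group: 2-hydroxyethoxy in place of octyl gives a 100-fold lower number from compound 3 to compound 4 (2.00 log units; beyond the scatter), so the large gap to octyl is not confined to the ethylsulfanyl and propoxy chains. The short chains can also be told apart here, which the first pair could not show: hydroxy in place of methyl gives a 2.1-fold higher number from compound 2 to compound 4 (0.32 log units; beyond the scatter), and 2-hydroxyethoxy in place of ethylsulfanyl gives a 2.2-fold higher number from compound 1 to compound 4 (0.34 log units; beyond the scatter), both modest steps. Nothing measured here gives a reason for these steps.

Among these compounds, chain length and the presence of oxygen or sulfur change together, so their separate contributions remain unresolved. From the compounds shown here alone, what a plain butyl chain would give, or an amine in place of the hydroxy, stays open.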